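Changing the chain on the amine of compound 2

The source may report more compounds than this note shows. Statements on the series, on what has been measured and on what is new or still open speak of the compounds shown alone.

Compound 1 `O=C1C=C(N2CC2)C(=O)c2nc(-c3ccccc3)ccc21` gives 3310 nM in a functional assay on NCI60 cells (Homo sapiens) for cytotoxicity; on this read-out lower numbers stand for stronger inhibition of growth and higher numbers for weaker inhibition of growth. Compound 2 `C=CCNC1=CC(=O)c2nc(-c3ccccc3)ccc2C1=O` gives 14100 nM.

Compound 2 has the highest of the two numbers. Its nearest neighbour is compound 1, whose number is lower by a gap beyond the usual scatter, so compound 1 inhibits growth more strongly than compound 2.

Compound 3 `COCCCNC1=CC(=O)c2nc(-c3ccccc3)ccc2C1=O` differs from compound 2 in one place: 2-methoxyethyl in place of vinyl on a saturated chain carbon bound to an amine nitrogen. Among the compounds with values here, the two measured compounds differ from each other in a different way, so no measured step shows what this kind of change does; the expectation rests on the structural change alone. The step from compound 2 to compound 3 in this assay is expected to stay within the scatter, with no clear direction, as a 1.1-fold higher number from compound 2 to compound 3 (0.03 log units; within the scatter) expresses. Compound 3 is therefore estimated at 15000 nM, within a range from 5000 nM to 45000 nM.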

Compound 3, concentration for total growth inhibition: 19100 nM
Compound 3: middle estimate off by 1.3-fold (0.10 log units), on the low side; the range from low to high includes it.
By their numbers in this assay, from the lowest: compound 1; then compounds 2 and 3 (each within the scatter of the next).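

In this assay, placing 2-methoxyethyl in place of vinyl on a saturated chain carbon bound to an amine nitrogen gives a 1.4-fold higher number from compound 2 to compound 3 (0.13 log units; within the scatter) as the step. Within the data shown here, this is the first reading of a change at this position, and it shows that compound 2 and compound 3 cannot be told apart on this read-out, even though the double bond has gone and a chain with an oxygen has entered. At least for this one pair, the chain on the amine can therefore carry either end group without a difference that stands clear of the scatter.

Still open, as far as these compounds go, is whether a chain ending in an amine or a carboxylic acid, or a much longer chain, would also stay within the scatter of compound 2. No measurement at hand offers a reason for this result.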